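Amide Variation on the Carbonyl of a Quinoline Series

The source may hold more compounds than are shown below. What is called first, only, known or untested is meant among the compounds shown, and "the series" means these compounds.

Three compounds have been measured in an assay on blood for inhibition of Indoleamine 2,3-dioxygenase 1 (Homo sapiens), read by mass spectrometry, with stated times of 4 h and 18 h; on this read-out higher numbers stand for weaker inhibition and lower numbers for stronger inhibition:
compound 1 `C[C@@H](CNc1ccc(Cl)cc1)[C@H]1CC[C@@H](c2ccnc3ccc(F)cc32)CC1` gives 44 nM
compound 2 `C[C@@H](NC(=O)c1cccc(Cl)c1)[C@H]1CC[C@@H](c2ccnc3ccc(F)cc32)CC1` gives 97 nM
compound 3 `C[C@@H](NC(=O)C12CCC(Cl)(CC1)CC2)[C@H]1CC[C@@H](c2ccnc3ccc(F)cc32)CC1` gives 579 nM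

Compound 3 has the highest number of the three; compound 2 is nearest to it and compound 1 furthest. Compound 4 `C[C@@H](NC(=O)C1CCCCC1)[C@H]1CC[C@@H](c2ccnc3ccc(F)cc32)CC1` differs from compound 3 by a group of 6 heavy atoms (6 carbon; one six-membered non-aromatic ring of carbon only) in place of a group of 9 heavy atoms (8 carbon, 1 chlorine; 2 six-membered non-aromatic rings of carbon only), on a carbonyl carbon. Among the measured compounds shown here, only one measured step bears on this change: a 6.0-fold higher number from compound 2 to compound 3 (0.78 log units; beyond the scatter), where the aromatic ring gave way to the saturated bicyclic group. Compound 4 keeps a saturated ring but loses the chlorine and the second ring, so it is expected to land between compound 2 and compound 3, with the step expected to be a 1.9-fold lower number from compound 3 to compound 4 (0.29 log units; within the scatter). The estimate for compound 4 is 300 nM, with a range from 100 nM to 900 nM.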

Compound 4, half-maximal inhibitory concentration: 294 nM
Compound 4: middle estimate off by 1.0-fold (0.01 log units), on the high side; low and high end bracket the measured number.
By their numbers in this assay, from the lowest: compound 1; then compound 2; then compounds 4 and 3 (each within the scatter of the next).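

In this assay, the step to cyclohexyl on the carbonyl carbon, a 2.0-fold lower number from compound 3 to compound 4 (0.29 log units; within the scatter), does not separate the two saturated groups. Cyclohexyl in place of 3-chlorophenyl gives a 3.0-fold higher number from compound 2 to compound 4 (0.48 log units; beyond the scatter), so both saturated groups shown stand above the 3-chlorophenyl amide. The wider gap, a 6.7-fold higher number from compound 1 to compound 4 (0.82 log units; beyond the scatter), comes with (cyclohexylcarbonyl)amino in place of ((4-chlorophenyl)amino)methyl on the saturated chain carbon. On these data alone, how an unsubstituted phenyl, or a cyclohexyl carrying an amine or a carboxylic acid, would read on this carbonyl carbon stays open. Nothing measured here accounts for these steps.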